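Replacing the guanidine-type group on the shared core

This account rests on a few compounds, and the source may have more. Where it says the series, first, only, none or still open, it means among the compounds named here.

Compound 1 `COc1ccc(-c2nc(/N=C(\N)N(C)C)sc2-c2ccc(OC)cc2)cc1` stands as the strongest inhibitor among the compounds with a number in a functional assay with Oryctolagus cuniculus as the target (a lower number here means a stronger inhibitor, a higher number a weaker inhibitor), where compound 1 gives 37 nM. Compound 3 `COc1ccc(-c2nc(CN(C)C)sc2-c2ccc(OC)cc2)cc1` gives 96 nM in this assay, a step of a 2.6-fold higher number from compound 1 to compound 3 (0.41 log units; beyond the scatter). Compound 2 `COc1ccc(-c2nc(/N=C(\N)NC3CCCCC3)sc2-c2ccc(OC)cc2)cc1` reaches only a limit of this assay, > 1000 nM. The step of an at least 27-fold higher number from compound 1 to compound 2 (1.43 log units; beyond the scatter) therefore rests on the limit of > 1000 nM in this assay, at which 1 of the 3 values shown sits, and is a bound, not a number.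

Compound 4 `COc1ccc(-c2nc(CNC(=O)CSC)sc2-c2ccc(OC)cc2)cc1` is not yet measured. Its change from compound 1 is a group of 7 heavy atoms (4 carbon, 1 nitrogen, 1 oxygen, 1 sulfur; no ring) in place of a group of 6 heavy atoms (3 carbon, 3 nitrogen; no ring), on an aromatic carbon. Among the measured compounds shown here, two measured steps bear on it: the loss of the group of 6 heavy atoms for a smaller one in compound 3 cost a 2.6-fold higher number from compound 1 to compound 3 (0.41 log units; beyond the scatter), while enlarging that group in compound 2 cost an at least 27-fold higher number from compound 1 to compound 2 (1.43 log units; beyond the scatter). Compound 4 both removes the group and enters a larger one, so a large weakening is expected, a 16-fold higher number from compound 1 to compound 4 (1.21 log units; beyond the scatter). Compound 4 is estimated at 600 nM in this assay, with a range from 150 nM to 3000 nM, and a real chance that only a limit is returned.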

Compound 4, half-maximal inhibitory concentration: < 100 nM
Compound 4: only a limit was reported (the forecaster's own chance of this, stated with the estimate: 35%); middle value at least 6.0-fold (0.77 log units) from the limit.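

Compound 4 is reported in this assay only as a limit, not as a number: the limit of < 100 nM in this assay, at which 1 of the 4 values shown sits.

The steps to compound 4 from compound 1 and from compound 3 cannot be read. Among the compounds shown here, the one readable step, an at least 10-fold lower number from compound 2 to compound 4 (1.00 log units; beyond the scatter), has limits at both ends, and it shows that this aromatic carbon can carry the ((((methylsulfanyl)methyl)carbonyl)amino)methyl group, with no guanidine-type group on the shared core, without the loss seen with the cyclohexylamino group.

The compounds shown leave open how far the true value of compound 4 lies from its limit, and so whether it matches or passes compound 1. They also leave open how a primary amine, a carboxylic acid or a longer chain in place of the methylsulfanyl end would read in this assay.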